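Hydroxy for Nitro on the Ester Aryl Ring

The source may report more compounds than this note shows. Statements on the series, on what has been measured and on what is new or still open speak of the compounds shown alone.

Three compounds sharing one core have been measured in a functional assay, read by spectrophotometry, with a stated time of 30 min; on this read-out lower numbers stand for stronger inhibition and higher numbers for weaker inhibition:

Compound 1, `COc1cc(C2CC(=NOC(=O)c3cccc(O)c3)CC(c3ccc(O)c(OC)c3)N2C)ccc1O`, gives 16500 nM.
Compound 2, `COc1cc(C2CC(=NOC(=O)c3ccccc3O)CC(c3ccc(O)c(OC)c3)N2C)ccc1O`, gives 15900 nM.
Compound 3, `COc1cc(C2CC(=NOC(=O)c3ccc([N+](=O)[O-])cc3)CC(c3ccc(O)c(OC)c3)N2C)ccc1O`, gives 79000 nM.

Compound 3 stands highest of the three; compound 1 is its nearest neighbour and compound 2 its furthest. Compound 4, `COc1cc(C2CC(=NOC(=O)c3ccc(O)cc3)CC(c3ccc(O)c(OC)c3)N2C)ccc1O`, differs from compound 3 by hydroxy in place of nitro on an aromatic carbon. Among the measured compounds shown here, two measured steps bear on this change: a 4.8-fold higher number from compound 1 to compound 3 (0.68 log units; beyond the scatter) and a 5.0-fold higher number from compound 2 to compound 3 (0.70 log units; beyond the scatter), both modest and beyond the scatter, while a 1.0-fold lower number from compound 1 to compound 2 (0.02 log units; within the scatter) shows that the two hydroxyphenyl esters sit together. Compound 4 carries a hydroxy group on the same ring as those two, so a step back toward their numbers is expected in this assay, namely a 4.4-fold lower number from compound 3 to compound 4 (0.64 log units; beyond the scatter). Compound 4 is therefore estimated at 18000 nM, with a range from 7000 nM to 45000 nM.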

Compound 4, half-maximal inhibitory concentration: 15100 nM
Compound 4: middle estimate off by 1.2-fold (0.08 log units), on the high side, within the range that was stated.
By their numbers in this assay, from the lowest: compounds 4, 2 and 1 (each within the scatter of the next); then compound 3.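

In this assay, the change from nitro to hydroxy on an aromatic carbon para to a large group is now read directly as a 5.2-fold lower number from compound 3 to compound 4 (0.72 log units; beyond the scatter) and no longer only through esters with their hydroxy group elsewhere on the ring. The 4-hydroxyphenyl ester also sits with the other two hydroxyphenyl esters, with a 1.1-fold lower number from compound 2 to compound 4 (0.02 log units; within the scatter) and a 1.1-fold lower number from compound 1 to compound 4 (0.04 log units; within the scatter) so that moving the hydroxy group around this ring shifts nothing beyond the scatter, and compound 3 alone stands apart. No measurement is at hand that accounts for the step from nitro to hydroxy.

Going by these compounds, whether an amine, a methoxy group or a carboxylic acid at this position would sit with the hydroxyphenyl esters or with compound 3 remains open. Also open, on these data alone, is whether a nitro group elsewhere on this ring would give a number like that of compound 3.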